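This account rests on a few compounds, and the source may have more. Where it says the series, first, only, none or still open, it means among the compounds named here.

Working notes on the series in a functional assay on HL-60 cells (Homo sapiens) for cytotoxicity, read by MTT assay, with a stated time of 4 days; a lower number here means a stronger inhibitor, a higher number a weaker inhibitor. Compound 1 `Cc1ccc(-c2cn(C[C@H]3c4c(ccc(O)c4C)[C@@H]4CC[C@@]5(C)C[C@]43CC5=O)nn2)cc1` gives only a limit of the assay in this assay, > 20000 nM. Compound 2 `C=C1C[C@]23C[C@@]1(O)CC[C@H]2c1ccc(O)c(C)c1[C@@H]3Cn1cc(-c2ccc(OC)cc2)nn1` likewise returns a limit, > 20000 nM. Compound 3 `C=C1C[C@]23C[C@@]1(O)CC[C@H]2c1ccc(O)c(C)c1[C@@H]3Cn1cc(-c2ccc(C)cc2)nn1` also returns a limit, > 20000 nM. The change from compound 3 to compound 2 is methoxy in place of methyl on an aromatic carbon; the step it made, a step that the two limits leave unreadable from compound 3 to compound 2, cannot be read because of the limit of > 20000 nM in this assay, at which 3 of the 3 values shown sit.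

Compound 4 `COc1ccc(-c2cn(C[C@H]3c4c(ccc(O)c4C)[C@@H]4CC[C@@]5(C)C[C@]43CC5=O)nn2)cc1` has not yet been measured. Its difference from compound 1 is methoxy in place of methyl on an aromatic carbon, the same change as from compound 3 to compound 2, at the same kind of place. The difference between the core of compound 1 and the core of compound 3 is not broken down here. The step expected from compound 1 to compound 4 is a step that the limit leaves unreadable from compound 1 to compound 4, set beside the unreadable measured step. That expectation rests on compound 1 sitting at the limit > 20000 nM and on (the limit of > 20000 nM in this assay, at which 3 of the 3 values shown sit). Compound 4 is accordingly expected near 30000 nM, most likely reported only as a limit, within an estimated range from 12000 nM to 100000 nM.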

Compound 4, half-maximal inhibitory concentration: > 20000 nM
Compound 4 gave a limit, no number; the forecaster's own chance of this, stated with the estimate: 85%; the middle value is on the limit's open side.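

Compound 4 returns only a limit in this assay, as compound 1 does, so no step can be read from compound 1 to compound 4: the limit of > 20000 nM in this assay, at which 4 of the 4 values shown sit. The compounds shown leave open whether methyl or methoxy, or the core of compound 1 set against the core of compound 3, makes any difference in this assay.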